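The source may report more compounds than this note shows. Statements on the series, on what has been measured and on what is new or still open speak of the compounds shown alone.

Compound 1 `COCCS(=O)(=O)N1CCN(c2ccc(OCC3CCN(C(=O)OC(C)C)CC3)cn2)CC1` gives 300 nM in a functional assay on CHO-K1 cells for agonist activity at Glucose-dependent insulinotropic receptor (Homo sapiens), read by a luciferase reporter, with a stated time of 5 h; on this read-out higher numbers stand for an effect only at larger amounts of compound and lower numbers for an effect already at smaller amounts.
Compound 2 `CCN(CC)S(=O)(=O)N1CCN(c2ccc(OCC3CCN(C(=O)OC(C)C)CC3)cn2)CC1` gives 1200 nM in this assay.
Compound 3 `CCCS(=O)(=O)N1CCN(c2ccc(OCC3CCN(C(=O)CC(C)C)CC3)cn2)CC1` gives 1600 nM in this assay.

Compound 3 carries the highest of the three numbers in this assay. Its value and that of compound 2 lie within the scatter of each other, so no order between them can be read; against compound 1 the gap is beyond the scatter. Among the measured compounds shown here, compound 3 differs from compounds 1 and 2 in more than one place, so no single step connects them.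

Compound 4 `CCCS(=O)(=O)N1CCN(c2ccc(OCC3CCN(C(=O)c4ccco4)CC3)cn2)CC1` is obtained from compound 3 by the change (furan-2-yl in place of isobutyl on a carbonyl carbon). For the measured compounds named here, the only measured single step, a 4.0-fold higher number from compound 1 to compound 2 (0.60 log units; beyond the scatter), concerns the sulfonyl end of the shared core, not the carbonyl end, and therefore does not bear on this change. Going by the values given here, with no measured step touching the carbonyl substituent, the expectation is that compound 4 shows no step beyond the scatter, a 1.3-fold lower number from compound 3 to compound 4 (0.12 log units; within the scatter), in this assay. Compound 4 is therefore estimated at 1200 nM, within a range from 400 nM to 4000 nM.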

Compound 4, half-maximal effective concentration: 2000 nM
For compound 4 the middle estimate is 1.7-fold (0.22 log units) below the measured one; measured number inside the range.
By their numbers in this assay, from the lowest: compound 1; then compounds 2, 3 and 4 (each within the scatter of the next).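

In this assay, furan-2-yl in place of isobutyl on a carbonyl carbon gives a 1.3-fold higher number from compound 3 to compound 4 (0.10 log units; within the scatter). Among the compounds shown here, this is the first single step read at the carbonyl end of the shared core, and it shows that a group with no ring and a five-membered aromatic ring with one hetero atom cannot be told apart at this position. The compounds shown offer no independent measurement that could account for this result.

From the compounds shown here alone, it remains open whether a phenyl ring, a cyclohexyl group or a chain ending in a dimethylamino group on the same carbonyl carbon would also stay within the scatter. Going by these compounds, it is equally open whether the swap would read the same with 2-methoxyethyl on the sulfonyl sulfur, the group carried by compound 1.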